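The source may hold more compounds than are shown below. What is called first, only, known or untested is meant among the compounds shown, and "the series" means these compounds.

Going by the values given here, compound 1 `C#CCOc1ccc2c(=O)c(-c3cc(OC)c(OC)cc3OC)coc2c1` gives 8050 nM in a functional assay on HCT-116 cells (Homo sapiens) for antiproliferative activity, read by MTT assay, with a stated time of 24 h (a higher number here means a weaker inhibitor, a lower number a stronger inhibitor), the highest of the two numbers measured so far; compound 2 `COc1cc(OC)c(-c2coc3cc(OCc4ccc(F)cc4)ccc3c2=O)cc1OC` gives 950 nM in the same assay. Compound 3 `COc1cc(OC)c(-c2coc3cc(OCc4ccc(C(F)(F)F)cc4)ccc3c2=O)cc1OC` differs from compound 1 by 4-(trifluoromethyl)phenyl in place of ethynyl on a saturated chain carbon bound to an oxygen on an aromatic ring. Among the compounds with values here, the only measured step that bears on this change is an 8.5-fold lower number from compound 1 to compound 2 (0.93 log units; beyond the scatter), in which a 4-fluorophenyl replaced the same ethynyl at the same place. A step of similar size toward a lower number is therefore expected here, namely an 8.1-fold lower number from compound 1 to compound 3 (0.91 log units; beyond the scatter). Compound 3 is estimated at 1000 nM, with a likely range from 400 nM to 2500 nM.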

Compound 3, half-maximal inhibitory concentration: 2440 nM
Beside the measured number, compound 3's estimate is 2.4-fold (0.39 log units) below it; measured number inside the range.
By their numbers in this assay, from the lowest: compound 2; then compound 3; then compound 1.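

In this assay, the 4-(trifluoromethyl)phenyl group also gives a lower number than ethynyl, with a 3.3-fold lower number from compound 1 to compound 3 (0.52 log units; beyond the scatter). So compounds 2 and 3 both improve on compound 1, but the size of the gain depends on what the new ring carries: trifluoromethyl in place of fluoro on an aromatic carbon gives a 2.6-fold higher number from compound 2 to compound 3 (0.41 log units; beyond the scatter). Nothing available explains this difference. Going by these compounds, it remains open how plain phenyl, or a ring bearing an amine or a methoxy group, would compare, and whether a longer alkyl chain without a ring would also lower the number.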